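A Vinyl Group Enters Where Every Value Is a Limit

The source may hold more compounds than are shown below. What is called first, only, known or untested is meant among the compounds shown, and "the series" means these compounds.

In a functional assay on KYSE-410 cells (Homo sapiens) for antiproliferative activity, read by MTT assay, with a stated time of 72 h (on this read-out higher numbers stand for weaker inhibition and lower numbers for stronger inhibition), compound 1 `O=C(Nc1ccc(OC(F)(F)F)cc1)c1cc(=O)[nH]c2cc(Br)ccc12` returns only the assay limit, > 20000 nM. Compound 2 `CC(C)(C)c1ccc(NC(=O)c2cc(=O)[nH]c3cc(Br)ccc23)cc1` likewise sits at the limit, > 20000 nM. The step that the two limits leave unreadable from compound 1 to compound 2 is thus left unreadable. Compound 3 `O=C(Nc1cccc(F)c1)c1cc(=O)[nH]c2cc(-c3ccccc3F)ccc12` also gives only the limit, > 20000 nM, so it stands with the other two at the limit of > 20000 nM in this assay, at which 3 of the 3 values shown sit, and no number separates them. Compound 4 `C=Cc1ccc2c(C(=O)Nc3cccc(F)c3)cc(=O)[nH]c2c1` differs from compound 3 by vinyl in place of 2-fluorophenyl on an aromatic carbon. Going by the values given here, no measured step bears readably on this change; every value shown is a limit. The expectation for compound 4 is accordingly a value near that limit, with the step of a number no higher from compound 3 to compound 4 (the limit leaves the size open) expected to be none beyond the scatter. Compound 4 is estimated at 20000 nM, within the range 6000 nM to 60000 nM.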

Compound 4, half-maximal inhibitory concentration: 13600 nM
Beside the measured number, compound 4's estimate is 1.5-fold (0.17 log units) above it; the measured number falls inside the stated range.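

In this assay, going by these compounds alone, vinyl in place of 2-fluorophenyl on this aromatic carbon gives the only value shown that is a number and not a limit, with an at least 1.4-fold lower number from compound 3 to compound 4 (0.16 log units; that floor lies within the scatter). The change therefore removes the ring and still leaves measurable antiproliferative activity, but no gain beyond the scatter can be claimed. Compound 3 gives only a limit, so the true size of the step stays open: the limit of > 20000 nM in this assay, at which 3 of the 4 values shown sit.

Going by these compounds, it remains open whether the double bond matters, which an ethyl group here would test. On these data alone, whether an amine or a carboxylic acid at this position would move the number is also open.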